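This account rests on a few compounds, and the source may have more. Where it says the series, first, only, none or still open, it means among the compounds named here.

Going by the values given here, in a functional assay on the whole organism (Tail, strain ICR) with Mus musculus as the target, in the tail flick test, with a stated time of 90 min, at a dose of 25 umol/kg by the oral route (a higher number here means a stronger effect of the compound at the dose given, a lower number a weaker effect), compound 1 `CC[C@H](C)[C@H](NC(=O)CN(c1ncnc2c1ncn2C1CCCCO1)C1CC1)C(=O)OCc1ccccc1` gives 22.6%, the lowest of the three numbers known so far. Compound 2 `O=C(O)CC[C@H](NC(=O)CN(c1nc(Cl)nc2[nH]cnc12)C1CC1)C(=O)O` gives 44.7% in the same test, and compound 3 `O=C(CN(c1nc(Cl)nc2[nH]cnc12)C1CC1)N[C@@H](CO)C(=O)O` gives 43.9%; each of these two stands beyond the scatter above compound 1, whereas the pair of compound 2 and compound 3 lie within the scatter of one another.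

Compound 4 `CC(C)C[C@H](NC(=O)CN(c1ncnc2c1ncn2C1CCCCO1)C1CC1)C(=O)OCc1ccccc1` differs from compound 1 in a single place: isobutyl in place of sec-butyl on a saturated chain carbon bound to an amide-type nitrogen and a carbonyl carbon.

Among the compounds with values here, the only step measured between neighbouring compounds, a number 0.8 percentage points lower from compound 2 to compound 3 (within the scatter), concerns a different group on a different core and says nothing about swapping one four-carbon chain for another; no step of that kind has been measured here. In the absence of any such guide, compound 4 is expected to remain close to compound 1, and the step of a number 0.6 percentage points lower from compound 1 to compound 4 (within the scatter) is expected to fall within the scatter. Compound 4 is therefore estimated at 22%, with a range expected from 8% to 38%.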

Compound 4, a percentage reported as activity, at one dose (the size of the read-out at that dose, not a potency): 28.2%
Beside the measured number, compound 4's estimate is 6.2 percentage points below it; measured number inside the range.
By their numbers in this assay, from the lowest: compounds 1 and 4 (each within the scatter of the next); then compounds 3 and 2 (each within the scatter of the next).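

In this assay, the step with isobutyl in place of sec-butyl on a saturated chain carbon bound to an amide-type nitrogen and a carbonyl carbon is a number 5.6 percentage points higher from compound 1 to compound 4 (within the scatter), the first step read at this position on the core of compound 1. With the atoms the same and only their joining changed, this swap of one four-carbon chain for another, which also gives up the defined stereocentre of sec-butyl, leaves compound 1 and compound 4 indistinguishable in this test. No measurement offered here accounts for this outcome.

From the compounds shown here alone, it remains open whether an aminobutyl chain, a longer chain such as hexyl or a phenyl ring at this place would shift the number beyond the scatter. Compound 2 and compound 3 differ from compound 4 in more than one place, so what separates their numbers from those of compound 1 and compound 4 also remains unresolved.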